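The source may report more compounds than this note shows. Statements on the series, on what has been measured and on what is new or still open speak of the compounds shown alone.

In a functional assay on CHO-K1 cells for antagonist activity at C-X-C chemokine receptor type 3 (Homo sapiens), read by FLIPR, with a stated time of 10 min (on this read-out higher numbers stand for weaker inhibition and lower numbers for stronger inhibition), two compounds have been measured. Compound 1 `O=C(Nc1ncccc1N1CCN(C(=O)Cn2cnc3cccnc32)CC1)c1cccc(Cl)c1` gives 177 nM, and compound 2 `Cc1nc(-c2nc3ccccc3[nH]2)c(N2CCN(C(=O)Cn3cnc4cccnc43)[C@H](C)C2)s1` gives 9 nM. On these two numbers compound 2 stands lowest; its nearest neighbour, compound 1, sits well beyond the usual scatter, so compound 2 is the stronger inhibitor of the pair.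

Compound 3 `C[C@@H]1CN(c2sc(CO)nc2-c2nc3ccccc3[nH]2)CCN1C(=O)Cn1cnc2cccnc21` has not yet been measured in this assay. It differs from compound 2 in a single place: hydroxy in place of hydrogen on a saturated chain carbon bound to an aromatic carbon. Cut one bond further out, the same change reads as methyl to hydroxymethyl.

No step between measured compounds bears on this change, so the direction cannot be read from the data shown. The alteration is small in heavy atoms, and the remainder of compound 2 is kept intact, so the step from compound 2 to compound 3 is expected to stay within, or only slightly beyond, the scatter of this assay, as a 1.3-fold higher number from compound 2 to compound 3 (0.12 log units; within the scatter). Compound 3 is therefore estimated at 12 nM, with a range from 4 nM to 40 nM.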

Compound 3, half-maximal inhibitory concentration: 171 nM
Estimate against measurement, compound 3: 14-fold (1.15 log units) below, and the stated range ends below it.
By their numbers in this assay, from the lowest: compound 2; then compounds 3 and 1 (each within the scatter of the next).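

In this assay, hydroxy in place of hydrogen on a saturated chain carbon bound to an aromatic carbon, which is the same change as methyl to hydroxymethyl, gives a 19-fold higher number from compound 2 to compound 3 (1.28 log units; beyond the scatter) and so lies well beyond the scatter. The earlier compounds shown here offered no step that differed in one place, so they could not show that this position matters to the read-out; this step shows that the potency of compound 2 is sensitive here, and that the entry of just 1 heavy atom, 1 oxygen, is enough to produce a large change. Nothing in the data shown gives a reason for the size of this step.

The compounds shown leave open whether the step belongs to the hydroxy itself or to any substituent on this methyl, since only methyl and hydroxymethyl stand at this place. An aminomethyl, a methoxymethyl, a carboxylic acid or a longer chain such as ethyl at the same place would separate these readings, and so would a plain hydrogen in place of the methyl.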